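A few compounds are considered here, and "the series" means these few. Any claim that something is new, unique, unknown or untested is made for them only; others in the source may bear on it.

Of the compounds shown here, three have been tested in a functional assay on PC-12 cells (Rattus norvegicus) for cytotoxicity, read by MTT assay, with stated times of 2 h and 24 h, tested at 1 uM; a lower number here means a weaker effect, a higher number a stronger effect of the compound at the concentration tested. Compound 1 `Oc1cc(C(F)(F)F)ccc1-c1nc(-c2ccccc2O)n(-c2ccc(Cl)cc2)n1` gives 68%, compound 2 `Oc1cc(C(F)(F)F)ccc1-c1nc(-c2ccccc2O)n(-c2ccc(C(F)(F)F)cc2)n1` gives 70.7%, and compound 3 `Oc1cc(C(F)(F)F)ccc1-c1nc(-c2ccccc2O)n(-c2cccc(Cl)c2)n1` gives 72.3%. Compound 2 differs from compound 1 by trifluoromethyl in place of chloro on an aromatic carbon, and this change made a step of a number 2.7 percentage points higher from compound 1 to compound 2 (within the scatter). The core of compound 3 differs from that of compound 1 by 3-chlorophenyl in place of 4-chlorophenyl on an aromatic nitrogen. Compound 4 `Oc1cc(C(F)(F)F)ccc1-c1nc(-c2ccccc2O)n(-c2cccc(C(F)(F)F)c2)n1` is not yet measured; it differs from compound 3 by trifluoromethyl in place of chloro on an aromatic carbon. The place is not the same in both pairs: in compound 1 the group sits para to a large group, in compound 3 meta to a large group, so this is the same kind of change, not the same one. Beside the earlier step, the step from compound 3 to compound 4 is expected to be a number 1.7 percentage points higher from compound 3 to compound 4 (within the scatter) because a number 2.7 percentage points higher from compound 1 to compound 2 (within the scatter) stayed within the scatter. Compound 4 is therefore estimated to give 74%, expected between 63% and 85%.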

Compound 4, a percentage reported as activity, at one concentration (the size of the read-out at that concentration, not a potency): 71.5%
Compound 4: the middle estimate sits 2.5 percentage points above what was measured, within the range that was stated.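

In this assay, trifluoromethyl in place of chloro gives a number 0.8 percentage points lower from compound 3 to compound 4 (within the scatter); 3-(trifluoromethyl)phenyl in place of 4-(trifluoromethyl)phenyl gives a number 0.8 percentage points higher from compound 2 to compound 4 (within the scatter), and in place of 4-chlorophenyl gives a number 3.5 percentage points higher from compound 1 to compound 4 (within the scatter). Set beside the earlier step, the same change shows no real difference between the two cores: the same change on two cores in this assay, a number 2.7 percentage points higher (within the scatter) from compound 1 to compound 2 and a number 0.8 percentage points lower (within the scatter) from compound 3 to compound 4, 3.5 percentage points apart, within the scatter of two such steps. So on both cores this swap leaves the read-out within the scatter at the one concentration tested, but this does not prove that the two steps are equal or that the swap would behave alike on other cores.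

All four compounds carry chloro or trifluoromethyl on the phenyl ring on the aromatic nitrogen. As far as these compounds go, what an amine, a methoxy group or a carboxylic acid would give there remains open.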